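Methoxy in place of chloro on compound 1

The compounds below may be only part of what the source reports. "The series", "measured", "known", "first", "only" and "open" are said of these compounds alone.

In a functional assay on SW620/5-FU cells (Homo sapiens) for cytotoxicity, read by MTT assay, with a stated time of 48 h, in the presence of a further agent that is not named here (on this read-out higher numbers stand for an effect only at larger amounts of compound and lower numbers for an effect already at smaller amounts), compound 1 (`COc1ccc(-c2cc(NNC(=O)Nc3cc(Cl)nc(Cl)c3)nc3c2cnn3C)cc1`) gives 18500 nM, the second highest of three numbers. Compound 2 (`COc1ccc(-c2cc(NNC(=O)Nc3cc(Cl)nc(Cl)c3)nc3c2c(C)nn3C)cc1`) gives 9700 nM, and compound 3 (`CCCc1cc(NNC(=O)Nc2cc(Cl)nc(Cl)c2)nc2c1cnn2C`) gives 38700 nM.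

Compound 4 (`COc1ccc(-c2cc(NNC(=O)Nc3cc(Cl)nc(OC)c3)nc3c2cnn3C)cc1`) has not yet been measured. It differs from compound 1 in one place: methoxy in place of chloro on an aromatic carbon. Methoxy stands in place of chloro on an aromatic carbon, next to the ring nitrogen, turning 2,6-dichloropyridin-4-yl into 2-chloro-6-methoxypyridin-4-yl.

Among the measured compounds shown here, no measured step touches this group. The two available steps lie elsewhere on the shared core and bear on the change only indirectly: a 1.9-fold lower number from compound 1 to compound 2 (0.28 log units; within the scatter) for methyl in place of hydrogen, and a 2.1-fold higher number from compound 1 to compound 3 (0.32 log units; beyond the scatter) for propyl in place of 4-methoxyphenyl. With both steps this small and nothing measured at the chloro group itself, no step beyond the scatter is expected in this assay. The expected step is a 1.1-fold higher number from compound 1 to compound 4 (0.03 log units; within the scatter). Compound 4 is estimated at 20000 nM, with an expected range of 8000 nM to 50000 nM.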

Compound 4, half-maximal effective concentration: 48800 nM
Beside the measured number, compound 4's estimate is 2.4-fold (0.39 log units) below it; measured number inside the range.
By their numbers in this assay, from the lowest: compounds 2 and 1 (each within the scatter of the next); then compounds 3 and 4 (each within the scatter of the next).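

In this assay, the first change shown at the 2,6-dichloropyridin-4-yl group moves the read-out: methoxy in place of chloro, next to the ring nitrogen, gives a 2.6-fold higher number from compound 1 to compound 4 (0.42 log units; beyond the scatter). This shows that the position is not indifferent to substitution, and the step runs in the same direction as that for propyl in place of 4-methoxyphenyl, a 2.1-fold higher number from compound 1 to compound 3 (0.32 log units; beyond the scatter). No measurement here accounts for the change at this position.

The compounds shown leave open whether the step comes from losing chloro or from gaining methoxy, which an amine or an ethoxy group at this place could help to separate. Going by these compounds, it also remains open whether the same change would give a similar step with the methyl group of compound 2 on the shared core, or at the remaining chloro group.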